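The source may report more compounds than this note shows. Statements on the series, on what has been measured and on what is new or still open speak of the compounds shown alone.

Measured compounds:
- compound 1, `COC(=O)Nc1cc(-c2cnc(OC[C@@](C)(N)CC(C)C)c(OC)c2)ccn1`: 3.8 nM
- compound 2, `CC(C)C[C@](C)(N)COc1cnc(-c2ccnc(Cl)c2)cc1Cl`: 2.3 nM

In an assay on isolated protein for inhibition of AP2-associated protein kinase 1 (Homo sapiens), with a stated time of 3 h, in the presence of a further agent that is not named here (on this read-out higher numbers stand for weaker inhibition and lower numbers for stronger inhibition), compound 1 gives 3.8 nM, the higher of the two numbers, while compound 2 gives 2.3 nM; the gap between them lies within the usual scatter, so neither stands apart. Compound 3, `COC(=O)Nc1cc(-c2cnc(OC[C@@](C)(N)CC(C)C)c(C#N)c2)ccn1`, differs from compound 1 in one place: cyano in place of methoxy on an aromatic carbon. For the measured compounds named here, no measured pair shows this kind of change, so nothing is known about its effect here. For compound 3 the expected step from compound 1 is a 1.3-fold higher number from compound 1 to compound 3 (0.12 log units; within the scatter), small and not clearly beyond the scatter. Compound 3 is therefore estimated at 5 nM, with a likely range from 1.5 nM to 16 nM.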

Compound 3, half-maximal inhibitory concentration: 1 nM
Beside the measured number, compound 3's estimate is 5.0-fold (0.70 log units) above it, outside the stated range (below it).
By their numbers in this assay, from the lowest: compound 3; then compounds 2 and 1 (each within the scatter of the next).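

In this assay, the aromatic carbon ortho to the (2-amino-2,4-dimethylpentyl)oxy group accepts cyano in place of methoxy, and the swap gives a 3.8-fold lower number from compound 1 to compound 3 (0.58 log units; beyond the scatter). This is stronger inhibition with the same count of heavy atoms in the group, so the identity of the group at this carbon matters. Nothing available explains why this step occurs.

Going by these compounds, whether trifluoromethyl or a carboxamide at this carbon would give a lower or higher number stays open. This single pair also cannot show whether the step carries over to a different core.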